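The compounds below may be only part of what the source reports. "The series", "measured", "known", "first", "only" and "open" are said of these compounds alone.

Measured in a functional assay on the whole organism (strain Wistar albino) for inhibition, with Rattus norvegicus as the target, read by paw edema, with a stated time of 3 h, at a dose of 25 mg/kg by the oral route; a higher number here means more inhibition at the dose given (going by the name of the read-out), a lower number less inhibition:
compound 1 `O=c1c2c(Nc3ccccc3)nn(-c3ccc([N+](=O)[O-])cc3)c2nc(Nc2ccccc2)n1-c1ccccc1` gives 14.1%
compound 2 `Cc1ccc(Nc2nn(-c3ccc([N+](=O)[O-])cc3)c3nc(Nc4ccccc4)n(-c4ccccc4)c(=O)c23)cc1` gives 30.2%
compound 3 `O=c1c2c(Nc3ccc(Cl)cc3)nn(-c3ccccc3)c2nc(Nc2ccccc2)n1-c1ccccc1` gives 28.7%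

Compound 3 stands second highest of the three. Its nearest neighbour is compound 2, whose value lies within the scatter of compound 3; the furthest is compound 1, which lies below compound 3 by more than the scatter. Compound 4 `O=c1c2c(Nc3ccc(Cl)cc3)nn(-c3ccc([N+](=O)[O-])cc3)c2nc(Nc2ccccc2)n1-c1ccccc1` differs from compound 3 by nitro in place of hydrogen on an aromatic carbon. For the measured compounds named here, the single measured one-place step, a number 16.1 percentage points higher from compound 1 to compound 2 (beyond the scatter), concerns a methyl group and does not bear on a nitro group; compound 1 and compound 3 differ in two places, so their values show only a gap. Going by the values given here, with no step bearing on the change, no shift beyond the scatter is expected in this assay. For compound 4 the estimate is 30%, ranging from 18% to 42%. The expected step is a number 1.3 percentage points higher from compound 3 to compound 4 (within the scatter).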

Compound 4, a percentage reported as inhibition, in the whole organism at one dose (the size of the read-out at that dose, not a potency): 20.6%
Beside the measured number, compound 4's estimate is 9.4 percentage points above it, within the range that was stated.
By their numbers in this assay, from the lowest: compounds 1, 4, 3 and 2 (each within the scatter of the next, the first and the last beyond it).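

In this assay, nitro in place of hydrogen on an aromatic carbon, read as phenyl to 4-nitrophenyl, gives a number 8.1 percentage points lower from compound 3 to compound 4 (within the scatter) and so shows no shift beyond the scatter at this position. With the nitro group kept, chloro in place of methyl gives a number 9.6 percentage points lower from compound 2 to compound 4 (within the scatter) and chloro in place of hydrogen gives a number 6.5 percentage points higher from compound 1 to compound 4 (within the scatter). Neither chloro step goes beyond the scatter, whereas the earlier methyl step was a number 16.1 percentage points higher from compound 1 to compound 2 (beyond the scatter). Nothing available explains these steps. As far as these compounds go, whether an amine or a carboxylic acid in place of the nitro group would read differently remains open.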